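Swapping Hydrogen for Ethyl on the Anilinic Nitrogen

The compounds below may be only part of what the source reports. "The series", "measured", "known", "first", "only" and "open" are said of these compounds alone.

Compound 3 `Cc1nc2ccc(CNc3ccc(C(=O)N[C@@H](CCC(=O)O)C(=O)O)cc3F)cc2c(=O)[nH]1` gives 9340 nM in an assay on isolated protein for inhibition of Thymidylate synthase (Mus musculus) (a lower number here means a stronger inhibitor, a higher number a weaker inhibitor), the highest of the three numbers in hand. Compound 1 `C=CCN(Cc1ccc2nc(C)[nH]c(=O)c2c1)c1ccc(C(=O)N[C@@H](CCC(=O)O)C(=O)O)cc1F` gives 5160 nM in this assay, and the step of a 1.8-fold higher number from compound 1 to compound 3 (0.26 log units; within the scatter) lies within the scatter. Within the data shown here, compound 2 `Cc1nc2ccc(CN(CC#N)c3ccc(C(=O)N[C@@H](CCC(=O)O)C(=O)O)c(F)c3)cc2c(=O)[nH]1` gives 170 nM in this assay, a far lower number, but no single-place step from compound 3 to compound 2 is available. Compound 4 `CCN(Cc1ccc2nc(C)[nH]c(=O)c2c1)c1ccc(C(=O)N[C@@H](CCC(=O)O)C(=O)O)cc1F` differs from compound 3 by ethyl in place of hydrogen on a nitrogen on an aromatic ring. Among the measured compounds shown here, the one step that bears on it, allyl against hydrogen, was small, so a small change at most is expected in this assay, if anything toward a lower number. Compound 4 is therefore expected to give 5000 nM, between 1500 nM and 15000 nM, a step of a 1.9-fold lower number from compound 3 to compound 4 (0.27 log units; within the scatter) that is estimated to stay within the scatter.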

Compound 4, half-maximal inhibitory concentration: 680 nM
For compound 4 the middle estimate is 7.4-fold (0.87 log units) above the measured one; measured number outside the range, below it.
By their numbers in this assay, from the lowest: compound 2; then compound 4; then compounds 1 and 3 (each within the scatter of the next).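

Ethyl in place of hydrogen on this nitrogen gives a 14-fold lower number from compound 3 to compound 4 (1.14 log units; beyond the scatter) as a large step in this assay and shows that a small chain here can matter greatly. A chain alone does not ensure this, and compound 1 goes against any such rule: a 1.8-fold higher number from compound 1 to compound 3 (0.26 log units; within the scatter) stays a small step with allyl. The end of the chain also counts, with methyl in place of vinyl giving a 7.6-fold lower number from compound 1 to compound 4 (0.88 log units; beyond the scatter) as a modest step.

From the compounds shown here alone, how a methyl group or a propyl chain on this nitrogen would compare remains open. Nothing shown gives a reason for the gap between ethyl and allyl.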